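The source may report more compounds than this note shows. Statements on the series, on what has been measured and on what is new or still open speak of the compounds shown alone.

Three compounds share one core and differ only in the group on the amide carbonyl. In an assay on HEK293 cells for displacement of a labelled ligand from Melanocortin receptor 4 (Homo sapiens) (a lower number here means a stronger inhibitor, a higher number a weaker inhibitor), compound 1 `COc1cc(CC(C)C(=O)N2CCN(c3ccc(C(F)(F)F)cc3[C@@H](N)CC(C)C)CC2)ccc1Cl` gives 230 nM. Compound 2 `CC(C)C[C@H](N)c1cc(C(F)(F)F)ccc1N1CCN(C(=O)[C@H](C)Cc2ccc(Cl)cc2)CC1` gives 31 nM in this assay. Compound 3 `CC(C)C[C@H](N)c1cc(C(F)(F)F)ccc1N1CCN(C(=O)COc2ccc(Cl)cc2)CC1` gives 2900 nM in this assay, the highest of the three numbers. The measured steps all lie beyond the scatter: a 7.4-fold lower number from compound 1 to compound 2 (0.87 log units; beyond the scatter), a 13-fold higher number from compound 1 to compound 3 (1.10 log units; beyond the scatter) and a 94-fold higher number from compound 2 to compound 3 (1.97 log units; beyond the scatter), so the acyl group is where the numbers move, and compound 3 stands clearly weaker than compound 1 and compound 2.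

Compound 4 `CC(C)C[C@H](N)c1cc(C(F)(F)F)ccc1N1CCN(C(=O)CCC2CCCCC2)CC1` is not yet measured. The change from compound 3 is cyclohexylmethyl in place of 4-chlorophenoxy on a saturated chain carbon bound to a carbonyl carbon. Among the compounds with values here, no measured step swaps an aromatic ether for a saturated ring on this chain, so nothing bears on it directly; what the steps do show is that this part of the molecule can shift the number by a large amount in either direction. Since compound 3 sits at the high end and the measured steps around it are large, the number for compound 4 is expected to differ from it, most likely downward, and the estimated step is a 2.9-fold lower number from compound 3 to compound 4 (0.46 log units; beyond the scatter). The estimate for compound 4 is 1000 nM, with a range from 150 nM to 6000 nM.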

Compound 4, inhibition constant: 5700 nM
Compound 4: the middle estimate sits 5.7-fold (0.76 log units) below what was measured; low and high end bracket the measured number.
By their numbers in this assay, from the lowest: compound 2; then compound 1; then compounds 3 and 4 (each within the scatter of the next).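

In this assay, putting cyclohexylmethyl in place of 4-chlorophenoxy on a saturated chain carbon bound to a carbonyl carbon gives a 2.0-fold higher number from compound 3 to compound 4 (0.29 log units; within the scatter), so compound 3 and compound 4 cannot be told apart even though the oxygen, the chlorine and the aromatic ring all leave. The 2-cyclohexylethyl group of compound 4 stands far from both branched groups, with a 180-fold higher number from compound 2 to compound 4 (2.26 log units; beyond the scatter) and a 25-fold higher number from compound 1 to compound 4 (1.39 log units; beyond the scatter), yet a chlorinated aromatic ring does not by itself go with a low number, as compound 3 carries one and still stands with compound 4 rather than with compound 1 or compound 2. No measurement shown here explains why these two different groups give numbers within the scatter of each other.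

The compounds shown leave open whether the lower numbers of compound 1 and compound 2 go with the branched chain or with the benzyl ring, which a 1-(cyclohexylmethyl)ethyl group or an unbranched 2-(4-chlorophenyl)ethyl group on the carbonyl carbon would help to separate. They also leave open what a longer chain, or an amine on the cyclohexane ring of compound 4, would do to the number.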